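The compounds below may be only part of what the source reports. "The series", "measured", "known", "first", "only" and "open" are said of these compounds alone.

Series notes, substituent on the amide-type nitrogen. Within the data shown here, compound 3 `Cc1ccc(OCC(=O)N(Cc2cccs2)c2ccccn2)cc1` gives 200 nM in an assay on HEK293 cells for agonist activity at transient receptor potential cation channel subfamily M member 8 (Homo sapiens), read by fluorescence and calcium flux, with a stated time of 15 min (a higher number here means that more compound is needed for the effect, a lower number that less compound is needed), and stands at the highest of the three numbers measured so far. Compound 1 `C=CCN(Cc1cccs1)C(=O)COc1ccc(C)cc1` gives 20 nM in this assay, and compound 2 `Cc1ccc(OCC(=O)N(Cc2cccs2)c2c(C)n[nH]c2C)cc1` gives 0.3 nM in this assay. All three steps among them are beyond the scatter: a 10-fold higher number from compound 1 to compound 3 (1.00 log units; beyond the scatter), a 67-fold lower number from compound 1 to compound 2 (1.82 log units; beyond the scatter) and a 670-fold higher number from compound 2 to compound 3 (2.82 log units; beyond the scatter).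

Compound 4 `COCCN(Cc1cccs1)C(=O)COc1ccc(C)cc1` is not yet measured. The change: 2-methoxyethyl in place of pyridin-2-yl on an amide-type nitrogen. The step that bears on it most directly is a 10-fold higher number from compound 1 to compound 3 (1.00 log units; beyond the scatter), where an allyl on the same nitrogen gave a clearly lower number than pyridin-2-yl; the 2-methoxyethyl of compound 4 is likewise a chain with no ring. The step of a 67-fold lower number from compound 1 to compound 2 (1.82 log units; beyond the scatter) shows how far a ring substituent can move the number, but 3,5-dimethyl-1H-pyrazol-4-yl plays no part here. Among the measured compounds shown here, no measured step covers 2-methoxyethyl itself, so the expectation rests on the allyl comparison alone, with added uncertainty. A lower number is expected for compound 4, of about the size a 6.7-fold lower number from compound 3 to compound 4 (0.82 log units; beyond the scatter). Compound 4 is estimated at 30 nM in this assay, within a range of 8 nM to 120 nM.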

Compound 4, half-maximal effective concentration: 400 nM
Compound 4: the middle estimate sits 13-fold (1.12 log units) below what was measured, outside the stated range (above it).
By their numbers in this assay, from the lowest: compound 2; then compound 1; then compounds 3 and 4 (each within the scatter of the next).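

In this assay, a 2.0-fold higher number from compound 3 to compound 4 (0.30 log units; within the scatter), so at this amide-type nitrogen the 2-methoxyethyl chain and the pyridin-2-yl ring are not told apart, and the presence or absence of a ring does not by itself sort the numbers. The two groups without a ring do separate, with a 20-fold higher number from compound 1 to compound 4 (1.30 log units; beyond the scatter), which shows that the change from vinyl to methoxymethyl on the saturated chain carbon bound to this nitrogen is enough to move the number well beyond the scatter. With a 1300-fold higher number from compound 2 to compound 4 (3.12 log units; beyond the scatter), the 3,5-dimethyl-1H-pyrazol-4-yl of compound 2 stands apart from all three other substituents, and among the four compounds the large drop in the number belongs to that group alone.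

Nothing shown gives a reason for these differences. Still open, going by these compounds, is whether a plain propyl chain, a longer alkyl chain or a 2-aminoethyl group on the same nitrogen would stay close to compound 1 or to compound 4, and whether a pyrazole ring without its two methyl groups would keep the number of compound 2.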